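The source may report more compounds than this note shows. Statements on the series, on what has been measured and on what is new or still open speak of the compounds shown alone.

The measured compounds. Compound 1 `O=C(OC1CCC(CN2CCN(c3cc(=O)c4cc(C(F)(F)F)cc([N+](=O)[O-])c4s3)CC2)CC1)c1ccccc1`: in an ADME assay on Vero cells (Chlorocebus sabaeus) for cytotoxicity, read by MTT assay, with a stated time of 48 h (a lower number here means a stronger inhibitor, a higher number a weaker inhibitor), compound 1 gives > 64 ug/mL, which is a limit of the assay and not a number. Compound 2 `O=C(NC1CCC(CN2CCN(c3cc(=O)c4cc(C(F)(F)F)cc([N+](=O)[O-])c4s3)CC2)CC1)c1ccccc1`: in this assay compound 2 gives 44.3 ug/mL. Compound 3 `O=C(OC1CCC(CN2CCN(c3cc(=O)c4cc(C(F)(F)F)cc([N+](=O)[O-])c4s3)CC2)CC1)c1ccco1`: in this assay compound 3 gives > 64 ug/mL, again a limit and not a number.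

Going by the values given here, compound 2 thus stands as the only number among the three; the other two results sit at the limit of > 64 ug/mL in this assay, at which 2 of the 3 values shown sit. The steps around it read accordingly: an at least 1.4-fold lower number from compound 1 to compound 2 (0.15 log units; that floor lies within the scatter), and an at least 1.4-fold higher number from compound 2 to compound 3 (0.15 log units; that floor lies within the scatter). Between compound 1 and compound 3 the two limits leave the step unreadable: a step that the two limits leave unreadable from compound 1 to compound 3.

Compound 4 `O=C(OC1CCC(CN2CCN(c3cc(=O)c4cc(C(F)(F)F)cc([N+](=O)[O-])c4s3)CC2)CC1)c1cccs1` is not yet measured. Its change from compound 2 is ((thiophen-2-yl)carbonyl)oxy in place of benzamido on a saturated ring carbon. This runs parallel to the step from compound 2 to compound 3, where ((furan-2-yl)carbonyl)oxy replaces benzamido, and that step was an at least 1.4-fold higher number from compound 2 to compound 3 (0.15 log units; that floor lies within the scatter). A higher number is therefore expected, most likely again only a limit, with a 1.8-fold higher number from compound 2 to compound 4 (0.26 log units; within the scatter). Compound 4 is expected to give 80 ug/mL in this assay, within 50 ug/mL to 160 ug/mL.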

Compound 4, half-maximal inhibitory concentration: > 64 ug/mL
Compound 4: a limit, no number; the forecaster's own chance of this, stated with the estimate: 70%; the middle value does not contradict the limit.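

With thiophen-2-yl on the carbonyl carbon, a third carbonyloxy group on the saturated ring carbon now reads as a limit in this assay: the limit of > 64 ug/mL in this assay, at which 3 of the 4 values shown sit.

Going by these compounds alone, putting ((thiophen-2-yl)carbonyl)oxy in place of benzamido gives an at least 1.4-fold higher number from compound 2 to compound 4 (0.15 log units; that floor lies within the scatter), so the reading seen with the furan-2-yl group recurs with a second five-membered aromatic ring, and compound 2 remains the one compound of the four that goes against this pattern. The steps among compound 1, compound 3 and compound 4 all join two limits and cannot be read, so no difference among their aromatic rings can be stated.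

From the compounds shown here alone, it remains open whether a furan-2-yl or thiophen-2-yl amide on the same saturated ring carbon would give a number as compound 2 does. Going by these compounds, it also remains open how a benzamido group carrying a methyl group in place of the amide hydrogen would read.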